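Swapping a Bulky Outer Ring for a Pyridine

The source may hold more compounds than are shown below. What is called first, only, known or untested is meant among the compounds shown, and "the series" means these compounds.

Three compounds share one core and differ only in one outer ring. In an assay on isolated protein for inhibition of protein deacetylase HDAC6 (Homo sapiens), read by mobility shift assay (a higher number here means a weaker inhibitor, a lower number a stronger inhibitor), compound 1 `O=C(NO)c1ccc(CN(Cc2ccc(F)cc2)S(=O)(=O)c2c(F)c(F)c(F)c(F)c2F)cc1` gives 13 nM. Compound 2 `Cc1ccc(CN(Cc2ccc(C(=O)NO)cc2)S(=O)(=O)c2c(F)c(F)c(F)c(F)c2F)cc1` gives 6 nM, and compound 3 `CC(C)(C)c1ccc(CN(Cc2ccc(C(=O)NO)cc2)S(=O)(=O)c2c(F)c(F)c(F)c(F)c2F)cc1` gives 42 nM, the highest of the three numbers. The measured steps are a 2.2-fold lower number from compound 1 to compound 2 (0.34 log units; beyond the scatter), a 3.2-fold higher number from compound 1 to compound 3 (0.51 log units; beyond the scatter) and a 7.0-fold higher number from compound 2 to compound 3 (0.85 log units; beyond the scatter). Compound 4 `O=C(NO)c1ccc(CN(Cc2ccncc2)S(=O)(=O)c2c(F)c(F)c(F)c(F)c2F)cc1` carries pyridin-4-yl in place of 4-(tert-butyl)phenyl on a saturated chain carbon bound to a sulfonamide nitrogen. Within the data shown here, no measured step makes this exact change. Because a 3.2-fold higher number from compound 1 to compound 3 (0.51 log units; beyond the scatter) shows the tert-butyl group with the highest number, taking it away is expected to lower the number, while the ring nitrogen is an unknown. The step from compound 3 to compound 4 is therefore expected to be a 2.8-fold lower number from compound 3 to compound 4 (0.45 log units; beyond the scatter). Compound 4 is expected to give about 15 nM, within 5 nM to 50 nM.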

Compound 4, half-maximal inhibitory concentration: 14 nM
Estimate against measurement, compound 4: 1.1-fold (0.03 log units) above, and the stated range covers the measured number.
By their numbers in this assay, from the lowest: compound 2; then compounds 1 and 4 (each within the scatter of the next); then compound 3.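

This position holds a ring containing nitrogen as readily as a carbon-only ring: in this assay the pyridin-4-yl group matches the 4-fluorophenyl group, with a 1.1-fold higher number from compound 1 to compound 4 (0.03 log units; within the scatter). Removing the 4-(tert-butyl)phenyl group gives a 3.0-fold lower number from compound 3 to compound 4 (0.48 log units; beyond the scatter), yet the 4-methylphenyl group keeps the lowest number, with a 2.3-fold higher number from compound 2 to compound 4 (0.37 log units; beyond the scatter). No evidence is available to explain these differences.

Open, from the compounds shown here alone, is how a plain phenyl ring would compare, which would separate the effect of the ring nitrogen from that of losing the outer group. Also open, going by these compounds, is how an amine or a carboxylic acid on this ring would read.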